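Pyrrolidinylethyl for tert-butyl on the amine nitrogen

The compounds below may be only part of what the source reports. "The series", "measured", "known", "first", "only" and "open" are said of these compounds alone.

For the measured compounds named here, compound 1 `CC(C)N/C(=N\C1=NC(=O)C(=O)N1C(C)C)Nc1ccc(Cl)c(Cl)c1` is the first of two measured members. In an in vitro ADME assay on microsomes from liver (Homo sapiens) for metabolic stability, read by LC-MS (a lower number here means that the compound disappears faster, a higher number that the compound lasts longer), compound 1 gives > 1 h, which is a limit of the assay and not a number. Compound 2 `CC(C)N1C(=O)C(=O)N=C1/N=C(/Nc1ccc(Cl)c(Cl)c1)NC(C)(C)C` is the second member. In this assay compound 2 gives > 1 h, again a limit of the assay. The step that the two limits leave unreadable from compound 1 to compound 2 is therefore not readable in size, because of the limit of > 1 h in this assay, at which 2 of the 2 values shown sit. Compound 3 `CC(C)N1C(=O)C(=O)N=C1/N=C(\NCCN1CCCC1)Nc1ccc(Cl)c(Cl)c1` is not yet measured. It differs from compound 2 by 2-(pyrrolidin-1-yl)ethyl in place of tert-butyl on an amine nitrogen. Going by the values given here, no measured step touches this position, and both known values are limits, so no size or direction is expected beyond a guess that compound 3 stays near where compound 2 stands. The step that the limit leaves unreadable from compound 2 to compound 3 is the estimate written here. Compound 3 is expected at 1.2 h, with a range from 0.5 h to 3 h.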

Compound 3, half-life: 0.886 h
Compound 3: middle estimate off by 1.4-fold (0.13 log units), on the high side; the range from low to high includes it.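

In this assay, for the compounds shown here, compound 3 gives 0.886 h, the first value that is a number and not a limit, so this amine nitrogen now carries a substituent with a readable half-life. Set against the tert-butyl and isopropyl groups, 2-(pyrrolidin-1-yl)ethyl gives an at least 1.1-fold lower number from compound 2 to compound 3 (0.05 log units; that floor lies within the scatter) and an at least 1.1-fold lower number from compound 1 to compound 3 (0.05 log units; that floor lies within the scatter), so neither step is shown to clear the scatter. Both steps are only floors, and their full size stays unread: the limit of > 1 h in this assay, at which 2 of the 3 values shown sit.

Still open, as far as these compounds go, is whether the half-life at this position follows the five-membered ring or the ethyl chain that carries it. A morpholine or piperidine ring on the same chain, a longer chain ending in pyrrolidine, or a simple hydroxyethyl group would separate the two.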